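Working notes: from compound 3 to compound 4

A few compounds are considered here, and "the series" means these few. Any claim that something is new, unique, unknown or untested is made for them only; others in the source may bear on it.

In a physicochemical assay for solubility, at pH 7.4 (a lower number here means a less soluble compound, a higher number a more soluble compound), compound 1 (`O=C(c1ccc(Cl)nc1)N1CCC(NS(=O)(=O)c2cc(S(=O)(=O)c3ccccc3)ccc2C(F)(F)F)CC1`) gives 1700 nM as a measured number. Compound 2 (`O=C(O)c1cccc(S(=O)(=O)N2CCC(NS(=O)(=O)c3cc(S(=O)(=O)c4ccccc4)ccc3C(F)(F)F)CC2)c1`) gives > 100000 nM and this is a limit, not a number. Compound 3 (`CC(C)(O)CCN1CCC(NS(=O)(=O)c2cc(S(=O)(=O)c3ccccc3)ccc2C(F)(F)F)CC1`) gives > 100000 nM and this too is a limit. Compound 3 thus sits at the limit of > 100000 nM in this assay, at which 2 of the 3 values shown sit, and the comparison with the other limit yields a step that the two limits leave unreadable from compound 2 to compound 3 and no more.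

Compound 4 (`O=C(C1CCNCC1)N1CCC(NS(=O)(=O)c2cc(S(=O)(=O)c3ccccc3)ccc2C(F)(F)F)CC1`) differs from it as follows: (piperidin-4-yl)carbonyl in place of 3-hydroxy-3-methylbutyl on an amine nitrogen in a ring and so it again has a carbonyl on that nitrogen, as compound 1 does, but without the 6-chloropyridin-3-yl part.

For the measured compounds named here, two measured steps bear on this. Both start from compound 1 and both are large: an at least 58-fold higher number from compound 1 to compound 2 (1.76 log units; beyond the scatter) and an at least 58-fold higher number from compound 1 to compound 3 (1.76 log units; beyond the scatter) with the (6-chloropyridin-3-yl)carbonyl gone each time. Compound 4 also lacks that group, so a high number is expected, though its retained carbonyl leaves room for a fall from the limit. The expected step is an at least 1.6-fold lower number from compound 3 to compound 4 (0.22 log units; that floor lies within the scatter) in this assay and its direction, if one shows, is estimated to be towards a lower number. Compound 4 is expected at 60000 nM within an estimated range of 12000 nM to 100000 nM.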

Compound 4, solubility: > 100000 nM
Compound 4: only a limit was reported; the forecaster's own chance of this, stated with the estimate: 45%; middle value at least 1.6-fold (0.22 log units) away from the limit.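

In this assay, exchanging only the 6-chloropyridin-3-yl on the carbonyl carbon for piperidin-4-yl gives an at least 58-fold higher number from compound 1 to compound 4 (1.76 log units; beyond the scatter), whereas the two earlier large steps replaced the whole (6-chloropyridin-3-yl)carbonyl. A carbonyl on this amine nitrogen in a ring is therefore now seen both in compound 1, which has a measured number, and in compound 4, which does not, so the carbonyl alone does not set the low number of compound 1. Compound 4 gives > 100000 nM, which is a limit and not a number, so the steps to it from compound 2 and from compound 3 cannot be read, and the top of the series now rests on one ceiling: the limit of > 100000 nM in this assay, at which 3 of the 4 values shown sit.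

As far as these compounds go, how far compound 2, compound 3 and compound 4 lie beyond that limit stays open, and with it any order among the three groups on the nitrogen. Also open, from the compounds shown here alone, is what the carbonyl carbon tolerates between the two groups seen there: an unsubstituted pyridin-3-yl or a cyclohexyl, with no ring nitrogen, could place a number between compound 1 and the limit.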